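Isopropyl to methyl on the core: metabolic stability notes

This account rests on a few compounds, and the source may have more. Where it says the series, first, only, none or still open, it means among the compounds named here.

In an ADME assay on microsomes from liver (Mus musculus) for metabolic stability, with a stated time of 30 min (on this read-out higher numbers stand for a more stable compound and lower numbers for a less stable compound), compound 1 `CCCCc1nc(C(C)C)c(CC(=O)OC)c(=O)n1Cc1ccc(-c2ccccc2-c2noc(=O)[nH]2)cc1` gives 9.4% and stands lowest of the two single numbers at hand. Among the measured compounds shown here, compound 2 `CCCCCOC(=O)Cc1c(C(C)C)nc(CCCC)n(Cc2ccc(-c3ccccc3-c3noc(=O)[nH]3)cc2)c1=O` gives 19.7%, the only step of one change that is measured: a number 10.3 percentage points higher from compound 1 to compound 2 (beyond the scatter). Compound 3 `CCCCc1nc(C)c(CC(=O)OCC)c(=O)n1Cc1ccc(-c2ccccc2-c2noc(=O)[nH]2)cc1` gives 12.9%; 78.4% (2 entries); its two entries differ widely, as shown by the several entries of compound 3 in this assay, 12.9%; 78.4% (2 entries), so compound 3 supplies no firm anchor.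

Compound 4 `CCCCc1nc(C)c(CC(=O)OC)c(=O)n1Cc1ccc(-c2ccccc2-c2noc(=O)[nH]2)cc1` carries methyl in place of isopropyl on an aromatic carbon. For the measured compounds named here, no measured step touches this position: the step from compound 1 to compound 2 concerns the ester chain, and compound 3 differs from compound 1 in two places and from compound 4 in one place with no measured single step between them. Going by the values given here, the change therefore rests on no precedent, and the expectation is a step within the scatter, a number 2.6 percentage points higher from compound 1 to compound 4 (within the scatter), in this assay. Compound 4 is thus estimated at 12%, with a range from 3% to 35%.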

Compound 4, percent of the compound remaining: 47.1%
For compound 4 the middle estimate is 35.1 percentage points below the measured one; the measured number lies above the stated range.
By their numbers in this assay, from the lowest: compound 1; then compound 2; then compound 4.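

Working notes: in this assay, the first measured change at this position gives a number 37.7 percentage points higher from compound 1 to compound 4 (beyond the scatter). This large step on the aromatic carbon next to the ring nitrogen exceeds the modest step in the ester chain, a number 10.3 percentage points higher from compound 1 to compound 2 (beyond the scatter), so among the single changes shown, replacing isopropyl with methyl has the greater effect on this read-out. Compound 3 also carries methyl here and differs from compound 4 only in the ester, but it gives no firm check on whether the rise holds with another ester: the several entries of compound 3 in this assay, 12.9%; 78.4% (2 entries).

With only isopropyl and methyl shown on this carbon, it remains open where hydrogen, ethyl or a cyclopropyl group would fall. Going by these compounds, it is also open whether methyl here and the longer pentyl ester chain of compound 2 would add together in one compound.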